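Benzylidenecyclohexanone series: chloro step from compound 3 to compound 4

The source may report more compounds than this note shows. Statements on the series, on what has been measured and on what is new or still open speak of the compounds shown alone.

Values in a functional assay on A549 cells (Homo sapiens) for cytotoxicity, read by MTT assay, with a stated time of 72 h; on this read-out lower numbers stand for stronger inhibition and higher numbers for weaker inhibition:
compound 1 `COc1ccc(/C=C2\CCC/C(=C\c3cccc(OC)c3OC)C2=O)cc1` gives > 20000 nM.
compound 2 `COc1ccc(/C=C2\CCC/C(=C\c3cccc(OC)c3OC)C2=O)c(OC)c1` gives > 20000 nM.
compound 3 `COc1ccc(/C=C2\CCC/C(=C\c3ccc(Cl)cc3)C2=O)cc1OC` gives 10100 nM.

For compound 1 the value is a limit of the assay, not a number. For compound 2 the value is likewise a limit. Among the compounds with values here, compound 3 is the only member with a number in this assay; the two other values are limits. Within the data shown here, the single measured step, a step that the two limits leave unreadable from compound 1 to compound 2, sits at the limit of > 20000 nM in this assay, at which 2 of the 3 values shown sit, at both ends and concerns methoxy in place of hydrogen on an aromatic carbon, so it does not bear on a chloro change.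

Compound 4 `COc1ccc(/C=C2\CCC/C(=C\c3ccc(Cl)cc3Cl)C2=O)cc1OC` differs from compound 3 by chloro in place of hydrogen on an aromatic carbon. Among the measured compounds shown here, no measured step in this assay covers such a change, so the expectation rests on compound 3 alone at 10100 nM. Compound 4 is estimated at 6000 nM, with a range from 2000 nM to 20000 nM. The expected step is a 1.7-fold lower number from compound 3 to compound 4 (0.23 log units; within the scatter), not clearly beyond the scatter.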

Compound 4, half-maximal inhibitory concentration: > 20000 nM
Compound 4: a limit, no number (the forecaster's own chance of this, stated with the estimate: 25%); middle value at least 3.3-fold (0.52 log units) from the limit.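

In this assay, within the data shown here, the change from 4-chlorophenyl to 2,4-dichlorophenyl, with the new chloro ortho to a large group, gives the first readable step for a chloro change (an at least 1.9-fold higher number from compound 3 to compound 4 (0.29 log units; that floor lies within the scatter)). Compound 4 gives a limit, not a number, so only a floor of the step is known, and no lower number appears at this position. Compound 4 joins the compounds at the limit: the limit of > 20000 nM in this assay, at which 3 of the 4 values shown sit.

As far as these compounds go, the true size of the step stays open. Also open, from the compounds shown here alone, is whether an amine or a carboxylic acid at this position would give a number.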